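From carboxymethoxy to hydroxy: does anything change?

The source may report more compounds than this note shows. Statements on the series, on what has been measured and on what is new or still open speak of the compounds shown alone.

- Compound 1 `O=C(Nc1ccc(F)c(-c2nc3ccccc3o2)c1)c1cc([N+](=O)[O-])ccc1Cl` gives > 25000 nM as a limit
- Compound 2 `O=C(O)COc1cc(Cl)c(C(=O)Nc2cccc(-c3nc4ccccc4s3)c2)cc1[N+](=O)[O-]` gives > 25000 nM as a limit
- Compound 3 `Cc1ccc(-c2nc3ccccc3s2)cc1NC(=O)c1cc([N+](=O)[O-])c(N2CCC(C(=O)O)CC2)cc1Cl` gives > 25000 nM as a limit

All three results come from an ADME assay on HepG2 cells (Homo sapiens) for cytotoxicity, with a stated time of 72 h (a lower number here means that less compound is needed, a higher number that more compound is needed for the effect), and each one is a limit of the assay and not a number. Compound 2 gives > 25000 nM as a limit. The whole set reads (the limit of > 25000 nM in this assay, at which 3 of the 3 values shown sit), so compound 2 stands level with the others, and no order can be drawn among them.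

Compound 4 `O=C(Nc1cccc(-c2nc3ccccc3s2)c1)c1cc([N+](=O)[O-])c(O)cc1Cl` has not yet been measured. Its difference from compound 2 is counted here: hydrogen in place of carboxymethyl on an oxygen on an aromatic ring. In words, hydrogen stands in place of carboxymethyl on an oxygen on an aromatic ring, which turns carboxymethoxy into hydroxy.

Within the data shown here, no two measured compounds differ in just one place, so no measured step gives the size of this change. Compound 1 carries no carboxymethoxy group and still gives > 25000 nM as a limit. No change beyond the usual scatter is therefore expected, and the assay may well report only a limit once more. The expected change is a number no higher from compound 2 to compound 4 (the limit leaves the size open) as an estimate. For compound 4 the estimated value is 25000 nM, with an expected range from 10000 nM to 50000 nM.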

Compound 4, half-maximal effective concentration: > 25000 nM
Compound 4: no number, only a limit; the forecaster's own chance of this, stated with the estimate: 80%; the middle value lies on the limit itself.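

In this assay compound 4 gives > 25000 nM, which is a limit of the assay and not a number. Compound 2 also gives only a limit, so the step between compound 2 and compound 4 cannot be read. The compounds shown leave open whether carboxymethoxy or hydroxy makes any difference to cytotoxicity, because every result is the same limit: the limit of > 25000 nM in this assay, at which 4 of the 4 values shown sit.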